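Methylation of the linking nitrogen in compound 2

The compounds below may be only part of what the source reports. "The series", "measured", "known", "first", "only" and "open" are said of these compounds alone.

Measured so far:
compound 1 `CCN(CC)c1ccc(C(=O)Nc2ccc(Oc3ncnc4ccsc34)cc2)cc1`: 8030 nM
compound 2 `c1cc(N2CCCCC2)nc(Nc2ccc(Oc3ncnc4sccc34)cc2)n1`: 4020 nM
compound 3 `CNC(=O)c1cc(Oc2ccc(Nc3nccc(N4CCCCC4)n3)cc2)ccn1`: 890 nM

In a functional assay on A549 cells (Homo sapiens) for inhibition, read by MTT assay, with a stated time of 72 h (on this read-out lower numbers stand for stronger inhibition and higher numbers for weaker inhibition), compound 2 gives 4020 nM, the second highest of the three numbers. Its nearest neighbour is compound 1, whose value of 8030 nM lies within the usual scatter of compound 2, so no order between the two can be read. Among the compounds with values here, the only step beyond the scatter runs a 4.5-fold lower number from compound 2 to compound 3 (0.65 log units; beyond the scatter), where the group on the ether oxygen is exchanged while the aminopyrimidine side is kept.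

Compound 4 `CN(c1ccc(Oc2ncnc3sccc23)cc1)c1nccc(N2CCCCC2)n1` is the next member. It differs from compound 2 by methyl in place of hydrogen on a nitrogen on an aromatic ring. Of the measured steps, none touches this nitrogen: the step from compound 2 to compound 3 alters the other end of the molecule and says nothing about the hydrogen on the linking nitrogen. There is therefore no measured basis for a directed change, and the expectation in this assay is a step within the scatter, with a slight lean toward a higher number as the hydrogen-bond donor count of the linker falls.

Compound 4 is estimated at 5500 nM, with a range of 1800 nM to 17000 nM, corresponding to an expected step of a 1.4-fold higher number from compound 2 to compound 4 (0.14 log units; within the scatter).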

Compound 4, half-maximal inhibitory concentration: 8790 nM
Estimate against measurement, compound 4: 1.6-fold (0.20 log units) below; the measured number falls inside the stated range.
By their numbers in this assay, from the lowest: compound 3; then compounds 2, 1 and 4 (each within the scatter of the next, the first and the last beyond it).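

In this assay, methyl in place of hydrogen on a nitrogen on an aromatic ring gives a 2.2-fold higher number from compound 2 to compound 4 (0.34 log units; beyond the scatter), the only step shown at this nitrogen; the step from compound 2 to compound 3 changed the group on an oxygen on an aromatic ring and left this nitrogen untouched. This nitrogen is therefore a place where even a methyl moves the number beyond the scatter, in the direction of weaker inhibition, although the step is modest and rests on this single pair. Nothing measured here accounts for the step, so no cause can be assigned to it.

On these data alone, it remains open whether the step is specific to methyl or extends to other replacements of this hydrogen, such as ethyl, a longer chain or an acetyl group on the same nitrogen. As far as these compounds go, it also remains open whether methyl on this nitrogen would give a step of similar size and direction with the group of compound 3 on the oxygen, since the present step is known only with the group of compound 2.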